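A few compounds are considered here, and "the series" means these few. Any claim that something is new, unique, unknown or untested is made for them only; others in the source may bear on it.

In a functional assay on HT-29 cells (Homo sapiens) for cytotoxicity, read by MTT assay, with a stated time of 2 days, tested at 10 uM (on this read-out lower numbers stand for less inhibition and higher numbers for more inhibition at the one concentration tested (going by the name of the read-out)), compound 1 `CCCCNc1nc(NCc2ccco2)c2cc(F)ccc2n1` gives 88.1%, and compound 2 `COc1ccc(Nc2nc(NCc3ccco3)c3cc(F)ccc3n2)cc1` gives 86.2%; the only step between them, a number 1.9 percentage points lower from compound 1 to compound 2 (within the scatter), is within the scatter, so compound 2 stands level with compound 1 on the numbers shown. Compound 3 `CCN(CC)CCNc1nc(NCc2ccco2)c2cc(F)ccc2n1` differs from compound 2 by 2-(diethylamino)ethyl in place of 4-methoxyphenyl on a nitrogen on an aromatic ring. For the measured compounds named here, the one measured step that bears on this, a number 1.9 percentage points lower from compound 1 to compound 2 (within the scatter), exchanged a chain for 4-methoxyphenyl at the same nitrogen without a change beyond the scatter, so no step beyond the scatter is expected for a number 0.2 percentage points lower from compound 2 to compound 3 (within the scatter). Compound 3 is therefore estimated at 86%, within 72% to 96%.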

Compound 3, a percentage reported as inhibition, at one concentration (the size of the read-out at that concentration, not a potency): 27.5%
Compound 3: middle estimate off by 58.5 percentage points, on the high side; measured number outside the range, below it.
By their numbers in this assay, from the lowest: compound 3; then compounds 2 and 1 (each within the scatter of the next).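

In this assay, the nitrogen on an aromatic ring proves far from indifferent to what it carries: a number 58.7 percentage points lower from compound 2 to compound 3 (beyond the scatter), with 2-(diethylamino)ethyl in place of 4-methoxyphenyl. The step of a number 60.6 percentage points lower from compound 1 to compound 3 (beyond the scatter), with diethylamino in place of ethyl on the saturated chain, is also large. Since compound 1 has no ring in this chain either, the loss of the ring alone cannot account for the fall.

Going by these compounds, whether a morpholine or a hydroxyl group at the chain end would keep the higher number remains open. Nothing shown explains the fall.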